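Substitution on the aromatic nitrogen of the shared core

The source may report more compounds than this note shows. Statements on the series, on what has been measured and on what is new or still open speak of the compounds shown alone.

Measured so far in a functional assay on HT-1080 cells (Homo sapiens) for cytotoxicity, read by MTT assay, with a stated time of 72 h; on this read-out lower numbers stand for stronger inhibition and higher numbers for weaker inhibition:
compound 1 `COc1cc(Nc2nc(C(=N)Nc3ccc(N4CCN(C)CC4)cc3)cc3c(-c4ccccc4)n[nH]c23)cc(OC)c1OC` — 3400 nM
compound 2 `COc1cc(Nc2nc(C(=N)Nc3ccccc3)cc3c(-c4ccccc4)n[nH]c23)cc(OC)c1OC` — 3900 nM
compound 3 `CN1CCN(c2ccc(NC(=N)c3cc4cn(C)nc4cn3)cc2)CC1` — 21000 nM

Compound 1 has the lowest number of the three; compound 2 sits within the scatter of it (a 1.1-fold higher number from compound 1 to compound 2 (0.06 log units; within the scatter)), while compound 3, a different core altogether, lies beyond it. Compound 4 `COc1ccc(Cn2nc(-c3ccccc3)c3cc(C(=N)Nc4ccc(N5CCN(C)CC5)cc4)nc(Nc4cc(OC)c(OC)c(OC)c4)c32)cc1` differs from compound 1 by 4-methoxybenzyl in place of hydrogen on an aromatic nitrogen. Within the data shown here, no measured step touches that aromatic nitrogen: the single step, from compound 1 to compound 2, concerns a remote part of the molecule and was within the scatter, and compound 3 differs in too many places to bear on it. In this assay the step from compound 1 to compound 4 is therefore expected to be a 1.3-fold higher number from compound 1 to compound 4 (0.12 log units; within the scatter), none beyond the scatter. Compound 4 is estimated at 4500 nM, in the range 1500 nM to 15000 nM.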

Compound 4, half-maximal inhibitory concentration: 1200 nM
Estimate against measurement, compound 4: 3.8-fold (0.57 log units) above; the whole stated range lies above it.
By their numbers in this assay, from the lowest: compound 4; then compounds 1 and 2 (each within the scatter of the next); then compound 3.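

In this assay, this aromatic nitrogen of the shared core need not carry hydrogen: 4-methoxybenzyl there gives a 2.8-fold lower number from compound 1 to compound 4 (0.45 log units; beyond the scatter). Among these compounds, this is the first step beyond the scatter, modest in size, and the number falls rather than rises with the added group. No measured evidence bears on the reason for this step.

Going by these compounds, it remains open whether this step is specific to 4-methoxybenzyl, since methyl, unsubstituted benzyl or a chain ending in an amine on this nitrogen would test that. On these data alone, whether the step carries over to compound 2 also remains open.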